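Huh-7 cytotoxicity: from furan-3-yl to 1-benzofuran-2-yl

A few compounds are considered here, and "the series" means these few. Any claim that something is new, unique, unknown or untested is made for them only; others in the source may bear on it.

Measured in a toxicity assay on Huh-7 cells (Homo sapiens) for cytotoxicity, with a stated time of 3 days; a lower number here means that less compound is tolerated, a higher number that more compound is tolerated:
- compound 1 `C[C@@]1(O)[C@H](O)[C@@H](CO)O[C@H]1n1cc(I)c2c(N)ncnc21`: 19800 nM
- compound 2 `C[C@@]1(O)[C@H](O)[C@@H](CO)O[C@H]1n1cc(-c2ccc3ccccc3c2)c2c(N)ncnc21`: 20100 nM
- compound 3 `C[C@@]1(O)[C@H](O)[C@@H](CO)O[C@H]1n1cc(-c2ccoc2)c2c(N)ncnc21`: > 44000 nM

Compound 3 stands at the limit of > 44000 nM in this assay, at which 1 of the 3 values shown sits, so it has a limit and not a number. Compound 4 `C[C@@]1(O)[C@H](O)[C@@H](CO)O[C@H]1n1cc(-c2cc3ccccc3o2)c2c(N)ncnc21` carries 1-benzofuran-2-yl in place of furan-3-yl (1-benzofuran-2-yl in place of furan-3-yl on an aromatic carbon). The nearest measured step is an at least 2.1-fold higher number from compound 2 to compound 3 (0.34 log units; beyond the scatter), and an at least 2.2-fold higher number from compound 1 to compound 3 (0.34 log units; beyond the scatter) is of similar size. For the measured compounds named here, the closest precedent for the larger group is compound 2, with 20100 nM. A modest step to a lower number is therefore expected in this assay, roughly the reverse of the step into compound 3. The estimate is an at least 1.8-fold lower number from compound 3 to compound 4 (0.26 log units; that floor lies within the scatter). For compound 4 the expected value is 24000 nM, with an estimated range of 11000 nM to 44000 nM.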

Compound 4, half-maximal cytotoxic concentration: 29400 nM
Beside the measured number, compound 4's estimate is 1.2-fold (0.09 log units) below it; measured number inside the range.
By their numbers in this assay, from the lowest: compounds 1, 2 and 4 (each within the scatter of the next). At a limit, above all of these: compound 3.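

In this assay, a second large group with two aromatic rings, 1-benzofuran-2-yl, gives no separation from naphthalen-2-yl or iodo: a 1.5-fold higher number from compound 2 to compound 4 (0.17 log units; within the scatter) and a 1.5-fold higher number from compound 1 to compound 4 (0.17 log units; within the scatter). Against furan-3-yl the change reads only as a floor, an at least 1.4-fold lower number from compound 3 to compound 4 (0.17 log units; that floor lies within the scatter), so no real difference from the single five-membered ring is established. Compound 3 holds a limit and not a number: the limit of > 44000 nM in this assay, at which 1 of the 4 values shown sits.

Still open, from the compounds shown here alone, is how far compound 3 lies past its limit. Also open, going by these compounds, is whether an amine or a short alkyl chain on this aromatic carbon would track compound 3 or the level shared by compounds 1, 2 and 4.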